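This account rests on a few compounds, and the source may have more. Where it says the series, first, only, none or still open, it means among the compounds named here.

Measured in a functional assay on MCF7 cells (Homo sapiens) for antiproliferative activity, read by MTT assay, with a stated time of 24 h; on this read-out higher numbers stand for weaker inhibition and lower numbers for stronger inhibition:
- compound 1 `CCn1c(C(=O)NCCC(=O)OC)ccc1C(CC)(CC)c1ccc(OCS(=O)(=O)c2ccccc2)c(C)c1`: > 50000 nM (a limit)
- compound 2 `CCn1c(C(=O)NC2(CO)CC2)ccc1C(CC)(CC)c1ccc(OCS(=O)(=O)c2ccccc2)c(C)c1`: 28800 nM
- compound 3 `CCn1c(C(=O)N[C@@H](CO)CCO)ccc1C(CC)(CC)c1ccc(OCS(=O)(=O)c2ccccc2)c(C)c1`: 27400 nM

Compound 1 gives only a limit of the assay, > 50000 nM. Compound 3, at 27400 nM, sits within the scatter of compound 2, and the step is small: a 1.1-fold lower number from compound 2 to compound 3 (0.02 log units; within the scatter).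

Compound 4 `CCn1c(C(=O)N[C@H](CO)CCCO)ccc1C(CC)(CC)c1ccc(OCS(=O)(=O)c2ccccc2)c(C)c1` changes only the group on the amide-type nitrogen: a group of 7 heavy atoms (5 carbon, 2 oxygen; no ring) in place of a group of 6 heavy atoms (4 carbon, 2 oxygen; no ring), on an amide-type nitrogen. The closest guide is that same swap on this nitrogen, a 1.1-fold lower number from compound 2 to compound 3 (0.02 log units; within the scatter), which stayed within the scatter. The steps of an at least 1.7-fold lower number from compound 1 to compound 2 (0.23 log units; that floor lies within the scatter) and an at least 1.8-fold lower number from compound 1 to compound 3 (0.26 log units; that floor lies within the scatter) are only floors, also within the scatter. The expected step is therefore none beyond the scatter: a 1.0-fold higher number from compound 3 to compound 4 (0.01 log units; within the scatter). Compound 4 is estimated at 28000 nM, with an expected range of 15000 nM to 50000 nM.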

Compound 4, half-maximal inhibitory concentration: 31400 nM
Compound 4: middle estimate off by 1.1-fold (0.05 log units), on the low side; the measured number falls inside the stated range.
By their numbers in this assay, from the lowest: compounds 3, 2 and 4 (each within the scatter of the next). At a limit, above all of these: compound 1.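

With the group of 7 heavy atoms on the amide-type nitrogen, the number in this assay stays within the scatter of both neighbours: a 1.1-fold higher number from compound 3 to compound 4 (0.06 log units; within the scatter) and a 1.1-fold higher number from compound 2 to compound 4 (0.04 log units; within the scatter). So this position has now taken three different hydroxyl-bearing groups without a step beyond the scatter. The comparison with the ester-bearing compound 1 remains only a floor, an at least 1.5-fold lower number from compound 1 to compound 4 (0.20 log units; that floor lies within the scatter), and compound 1 itself gives a limit, not a number: the limit of > 50000 nM in this assay, at which 1 of the 4 values shown sits.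

Still open, on these data alone, is whether an amine or a carboxylic acid on this nitrogen, or a much longer chain, would move the number beyond the scatter.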